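Methyl to Fluoro on the Aryl Amide: Expected Tolerance

The source may hold more compounds than are shown below. What is called first, only, known or untested is meant among the compounds shown, and "the series" means these compounds.

Measured compounds:
Compound 1 `COc1ccc2c(=O)c(/C=C/C(=O)Nc3ccc(C)cc3)coc2c1` gives 979000 nM in an ADME assay on HepG2 2.2.15 cells (Homo sapiens) for cytotoxicity, read by MTT assay, with stated times of 48 h and 9 days; a higher number here means that more compound is tolerated, a lower number that less compound is tolerated.
Compound 2 `COc1ccc2c(=O)c(/C=C/C(=O)Nc3ccccc3)coc2c1` gives 523000 nM.
Compound 3 `COc1cccc(NC(=O)/C=C/c2coc3cc(OC)ccc3c2=O)c1` gives 1130000 nM.

Compound 1 stands second highest of the three: compound 3 is nearest, with a 1.2-fold higher number from compound 1 to compound 3 (0.06 log units; within the scatter), and compound 2 furthest, with a 1.9-fold lower number from compound 1 to compound 2 (0.27 log units; within the scatter), both within the scatter. Compound 4 `COc1ccc2c(=O)c(/C=C/C(=O)Nc3ccc(F)cc3)coc2c1` differs from compound 1 by fluoro in place of methyl on an aromatic carbon. Among the measured compounds shown here, the step that bears most on this is the exchange at the same aromatic carbon, a 1.9-fold lower number from compound 1 to compound 2 (0.27 log units; within the scatter), which did not leave the scatter; the only step beyond it, a 2.2-fold higher number from compound 2 to compound 3 (0.33 log units; beyond the scatter), was modest. Therefore no step beyond the scatter is expected in this assay for this change. Compound 4 is estimated at 800000 nM, in the range 400000 nM to 1600000 nM, meaning an expected 1.2-fold lower number from compound 1 to compound 4 (0.09 log units; within the scatter).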

Compound 4, half-maximal cytotoxic concentration: 743000 nM
Compound 4: the middle estimate sits 1.1-fold (0.03 log units) above what was measured; measured number inside the range.
By their numbers in this assay, from the lowest: compounds 2, 4, 1 and 3 (each within the scatter of the next, the first and the last beyond it).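

In this assay, fluoro on this aromatic carbon stays within the scatter of methyl, with a 1.3-fold lower number from compound 1 to compound 4 (0.12 log units; within the scatter), and of hydrogen, with a 1.4-fold higher number from compound 2 to compound 4 (0.15 log units; within the scatter). Exchanging the 3-methoxyphenyl group for 4-fluorophenyl also stays within the scatter, with a 1.5-fold lower number from compound 3 to compound 4 (0.18 log units; within the scatter), so compound 4 lies within the scatter of all three earlier compounds. No measurement shown offers an explanation for these small differences.

Still open, as far as these compounds go, is whether an amine or a carboxylic acid on this carbon would produce a step beyond the scatter. The same question applies to a longer chain there.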